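This account rests on a few compounds, and the source may have more. Where it says the series, first, only, none or still open, it means among the compounds named here.

Measured so far:
- compound 1 `Cc1ccc2c(c1)/C(=N/NC(=S)Nc1ccccc1)C(=O)N2`: > 25000 nM
- compound 2 `O=C1Nc2ccccc2/C1=N/NC(=S)Nc1ccccc1`: > 25000 nM
- compound 3 `CN1C(=O)/C(=N\NC(=S)Nc2ccccc2)c2ccccc21`: > 25000 nM

In an ADME assay on RD cells (Homo sapiens) for cytotoxicity (on this read-out higher numbers stand for lower toxicity in this test and lower numbers for higher toxicity in this test), compound 2 gives only a limit, > 25000 nM. The same holds for compound 1, whose value in this assay is also a limit. Compound 3 likewise sits at a limit. Compound 4 `CCCNC(=S)N/N=C1\C(=O)Nc2ccccc21` is not yet measured; it differs from compound 2 by propyl in place of phenyl on an amide-type nitrogen.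

The two measured steps that touch compound 2, a step that the two limits leave unreadable from compound 1 to compound 2 and a step that the two limits leave unreadable from compound 2 to compound 3, are both unreadable in size, because of the limit of > 25000 nM in this assay, at which 3 of the 3 values shown sit. Within the data shown here, neither involves the group changed here, so no measured step bears directly on the change to compound 4. Among the measured compounds shown here, with every value so far at the limit, the expectation for compound 4 in this assay is again a limit rather than a number, with an expected step that the limit leaves unreadable from compound 2 to compound 4. Compound 4 is therefore estimated at 30000 nM, within 12000 nM to 100000 nM.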

Compound 4, half-maximal cytotoxic concentration: > 25000 nM
Compound 4 was reported as a limit; the forecaster's own chance of this, stated with the estimate: 80%; the middle value is on the limit's open side.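

Compound 2 and compound 4 are both limits, so no size can be read for the step between them: the limit of > 25000 nM in this assay, at which 4 of the 4 values shown sit. The compounds shown leave open where any of the four actually falls in this assay.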